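Ring size change on the amide chain of compound 2

The compounds below may be only part of what the source reports. "The series", "measured", "known", "first", "only" and "open" are said of these compounds alone.

Compound 2 `O=C(CN1CCCC1)Nc1ccc(-c2nc3ccccc3[nH]2)cc1` gives 40000 nM in an ADME assay on MT4 cells (Homo sapiens) for cytotoxicity, read by MTT assay, with a stated time of 96 h (a lower number here means that less compound is tolerated, a higher number that more compound is tolerated), the highest of the two numbers recorded so far. Among the compounds with values here, its only comparator, compound 1 `O=[N+]([O-])c1ccc(-c2nc3cc(C(F)(F)F)ccc3[nH]2)cc1`, is built on a different core, and in this assay compound 1 gives 6000 nM, a clearly lower number; no step between the two is recorded, so only the two values themselves can be set side by side. Compound 3 `O=C(CN1CCCCC1)Nc1ccc(-c2nc3ccccc3[nH]2)cc1` has not yet been measured. It differs from compound 2 in one place: piperidin-1-yl in place of pyrrolidin-1-yl on a saturated chain carbon bound to a carbonyl carbon. The carbonyl, the amide and the shared core stay untouched, and only the saturated ring at the end of the chain is altered. Within the data shown here, nothing among the measured compounds speaks to this kind of change, so the expected step from compound 2 to compound 3 in this assay is small, within the scatter, with no direction favoured. On that basis compound 3 is expected to give 40000 nM in this assay, with a range from 15000 nM to 100000 nM. This estimate means a step of no change at the digits printed from compound 2 to compound 3 (within the scatter).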

Compound 3, half-maximal cytotoxic concentration: 31000 nM
Beside the measured number, compound 3's estimate is 1.3-fold (0.11 log units) above it, within the range that was stated.
By their numbers in this assay, from the lowest: compound 1; then compounds 3 and 2 (each within the scatter of the next).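

Within the data shown here, this step gives the first reading of a change at one place: in this assay, piperidin-1-yl in place of pyrrolidin-1-yl on a saturated chain carbon bound to a carbonyl carbon gives a 1.3-fold lower number from compound 2 to compound 3 (0.11 log units; within the scatter), which lies within the scatter. Compound 1 and compound 2 differ in more than one place, so their values could not show what a single change at the end of the chain does, whereas this pair isolates that change with the amide and the shared core kept the same. Within this one pair, the five-membered and six-membered rings cannot be told apart in this assay, and nothing shown gives a reason for that outcome.

What the compounds shown leave open is whether this position responds to a change of another kind, since both groups here are saturated rings with one hetero atom. A dimethylamino group, a carboxylic acid or a longer chain between the carbonyl and the ring could still give a step beyond the scatter, and a single pair cannot say whether it would.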